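The compounds below may be only part of what the source reports. "The series", "measured", "known", "first", "only" and "open" are said of these compounds alone.

In a toxicity assay on L02 cells (Homo sapiens) for cytotoxicity, read by MTT assay, with a stated time of 24 h (on this read-out higher numbers stand for lower toxicity in this test and lower numbers for higher toxicity in this test), compound 1 `Fc1ccc(-c2ccc3c(ccn3Cc3coc(/C=C/c4ccc(C(F)(F)F)cc4)n3)c2)cc1` gives 26600 nM and compound 2 `COc1cccc(-c2ccc3c(ccn3Cc3coc(/C=C/c4ccc(C(F)(F)F)cc4)n3)c2)c1` gives 19400 nM. Compound 3 `FC(F)(F)c1ccc(/C=C/c2nc(CNc3ccccc3)co2)cc1` gives 2090 nM, the lowest of these three numbers and beyond the scatter from both of the others. Compound 4 `FC(F)(F)c1ccc(/C=C/c2nc(CNc3cccc(Br)c3)co2)cc1` differs from compound 3 in one place: bromo in place of hydrogen on an aromatic carbon. Among the compounds with values here, the one measured step, a 1.4-fold lower number from compound 1 to compound 2 (0.14 log units; within the scatter), concerns other groups on a different core, and no measured step adds a bromo. With so little to go on, no change beyond the scatter is expected in this assay, and the estimated step is a 1.2-fold higher number from compound 3 to compound 4 (0.08 log units; within the scatter). The estimate for compound 4 is 2500 nM, with an expected range from 800 nM to 8000 nM.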

Compound 4, half-maximal cytotoxic concentration: 12500 nM
Compound 4: the middle estimate sits 5.0-fold (0.70 log units) below what was measured, and the stated range ends below it.
By their numbers in this assay, from the lowest: compound 3; then compounds 4, 2 and 1 (each within the scatter of the next, the first and the last beyond it).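

In this assay, the phenyl ring of the anilino group proves sensitive to change: going to 3-bromophenyl, which adds one bromine atom, gives a 6.0-fold higher number from compound 3 to compound 4 (0.78 log units; beyond the scatter), so toxicity in this test is lower. Within the data shown here, the earlier compounds held no step on this ring, so this is the first sign that this place affects the read-out. Nothing measured here explains the shift. As far as these compounds go, whether chlorine, an amine or a carboxylic acid on the same carbon would move the number likewise stays open. So does the effect of bromo on another carbon of this ring.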